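The source may hold more compounds than are shown below. What is called first, only, known or untested is meant among the compounds shown, and "the series" means these compounds.

In a functional assay on PANC-1 cells (Homo sapiens) for cytotoxicity, read by MTT assay, with a stated time of 48 h, in the presence of a further agent that is not named here (on this read-out higher numbers stand for weaker inhibition and lower numbers for stronger inhibition), compound 1 `O=C(c1ccc2cccc(OCc3ccc(B(O)O)cc3)c2n1)N1CCC(Oc2no[n+]([O-])c2S(=O)(=O)c2ccccc2)CC1` gives 2690 nM and compound 2 `CC1(C)OB(c2ccc(COc3cccc4ccc(C(=O)N5CCC(Oc6no[n+]([O-])c6S(=O)(=O)c6ccccc6)CC5)nc34)cc2)OC1(C)C` gives 3470 nM, so these two values lie within the usual scatter of each other. Compound 3 `O=C(c1ccc2cccc(O)c2n1)N1CCC(Oc2no[n+]([O-])c2S(=O)(=O)c2ccccc2)CC1` differs from compound 1 by a hydrogen atom in place of a group of 10 heavy atoms (7 carbon, 1 boron, 2 oxygen; one six-membered aromatic ring of carbon only), on an oxygen on an aromatic ring. Among the measured compounds shown here, the only measured step, a 1.3-fold higher number from compound 1 to compound 2 (0.11 log units; within the scatter), alters just part of the group that leaves here, and no measured pair removes that group whole, so the guide is weak. The expected step is a 1.1-fold lower number from compound 1 to compound 3 (0.03 log units; within the scatter), which means no shift beyond the scatter is anticipated. For compound 3 the estimated value is 2500 nM, with an expected range from 800 nM to 8000 nM.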

Compound 3, half-maximal inhibitory concentration: 1320 nM
For compound 3 the middle estimate is 1.9-fold (0.28 log units) above the measured one; the range from low to high includes it.
By their numbers in this assay, from the lowest: compound 3; then compounds 1 and 2 (each within the scatter of the next).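

In this assay there is a 2.0-fold lower number from compound 1 to compound 3 (0.31 log units; beyond the scatter) when the whole boron-bearing group on the oxygen gives way to a hydrogen atom. Changing only the boron end of that group had moved the number within the scatter, whereas this change goes beyond it, so the complete group is not needed for activity here, and the core alone does at least as well. No evidence here explains the shift. Going by these compounds, whether a small group on that oxygen, such as methyl, would behave like the hydrogen atom remains open, as does the effect of a plain benzyl group without boron.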